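The source may hold more compounds than are shown below. What is called first, only, known or untested is meant among the compounds shown, and "the series" means these compounds.

In a functional assay on SMMC-7721 cells (Homo sapiens) for cytotoxicity, read by MTT assay, with a stated time of 72 h (on this read-out lower numbers stand for stronger inhibition and higher numbers for weaker inhibition), compound 1, `O=C(CSC(=S)N[C@H]1CCOC1=O)Nc1ccc(Br)cc1`, gives 28300 nM. Compound 2, `O=C(CSC(=S)N[C@H]1CCOC1=O)Nc1ccc(F)cc1`, is the matching compound in which the change fluoro in place of bromo on an aromatic carbon has been made. In this assay the value recorded for compound 2 is > 128000 nM, which is a limit of the assay rather than a number, as stated by the limit of > 128000 nM in this assay, at which 1 of the 3 values shown sits. The step of an at least 4.5-fold higher number from compound 1 to compound 2 (0.65 log units; beyond the scatter) is therefore known only as a lower bound on its size.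

Compound 3, `O=C(CCl)Nc1ccc(C(=O)/C=C/c2ccc(Br)cc2)cc1`, has a different core; how the core of compound 3 differs from the core of compound 1 is not broken down here. In this assay compound 3 gives 13300 nM, the lowest of the two numbers available, and a step beyond the scatter away from compound 1.

Compound 4, `O=C(CCl)Nc1ccc(C(=O)/C=C/c2ccc(F)cc2)cc1`, has not yet been measured. It differs from compound 3 by fluoro in place of bromo on an aromatic carbon, the same change that separates compound 1 from compound 2, made at the same kind of place. The expectation for compound 4 rests on the step of an at least 4.5-fold higher number from compound 1 to compound 2 (0.65 log units; beyond the scatter) seen on the other core. On that basis compound 4 is expected to show a 4.1-fold higher number from compound 3 to compound 4 (0.62 log units; beyond the scatter) in this assay. Compound 4 is expected at 55000 nM, with a range estimated from 18000 nM to 150000 nM. Whether this holds awaits the measurement.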

Compound 4, half-maximal inhibitory concentration: 15100 nM
For compound 4 the middle estimate is 3.6-fold (0.56 log units) above the measured one; the measured number lies below the stated range.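

On the core of compound 3, fluoro in place of bromo on the aromatic carbon gave a 1.1-fold higher number from compound 3 to compound 4 (0.06 log units; within the scatter), so in this assay this pair shows no separation, whereas the same change on the core of compound 1 gave a clear loss of inhibition. The change therefore did not carry over from one core to the other with the same effect, and a step seen on one core was no safe guide to the step on the other in this series: the same change on two cores in this assay, an at least 4.5-fold higher number (0.65 log units; beyond the scatter) from compound 1 to compound 2 and a 1.1-fold higher number (0.06 log units; within the scatter) from compound 3 to compound 4, at least 3.9-fold (0.60 log units) apart, beyond the scatter of two such steps.

Compound 2 stands at a limit of the assay and not at a number, so the size of the first step is known only as a lower bound, and with one pair on each core the comparison does not show which feature of the cores sets the two steps apart: the limit of > 128000 nM in this assay, at which 1 of the 4 values shown sits.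

The compounds shown leave open how either core would respond to a chloro, a methoxy or an amine on the same aromatic carbon, and whether any such group would separate the two cores as fluoro and bromo did. They also leave open whether the contrast between the two cores would hold in a different cell line.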